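A few compounds are considered here, and "the series" means these few. Any claim that something is new, unique, unknown or untested is made for them only; others in the source may bear on it.

Compound 1 `O=C(NO)c1ccc(CN(C2CC2)S(=O)(=O)c2cc(F)c(F)c(F)c2F)cc1` gives 3000 nM
Compound 2 `CC(C)N(Cc1ccc(C(=O)NO)cc1)S(=O)(=O)c1c(F)c(F)c(F)c(F)c1F` gives 2300 nM

In a toxicity assay on cells (Fibroblast, Homo sapiens) for inhibition, with a stated time of 72 h (on this read-out lower numbers stand for stronger inhibition and higher numbers for weaker inhibition), compound 2 gives 2300 nM and lies within the scatter of compound 1, so neither stands apart. Compound 3 `CC(C)N(Cc1ccc(C(=O)NO)cc1)S(=O)(=O)c1cc(F)c(F)c(F)c1F` differs from compound 2 by hydrogen in place of fluoro on an aromatic carbon. Going by the values given here, no measured step shows what this change does, so no step beyond the scatter is expected in this assay for compound 3. The expected change is a 1.2-fold higher number from compound 2 to compound 3 (0.07 log units; within the scatter) as an estimate. For compound 3 the estimated value is 2700 nM with an expected range from 1200 nM to 6000 nM in this read-out.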

Compound 3, half-maximal inhibitory concentration: 12400 nM
Beside the measured number, compound 3's estimate is 4.6-fold (0.66 log units) below it; measured number outside the range, above it.
By their numbers in this assay, from the lowest: compounds 2 and 1 (each within the scatter of the next); then compound 3.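

In this assay, going by these compounds alone, the earlier compounds showed no step; here, hydrogen in place of fluoro on the aromatic carbon ortho to a large group gives a 5.4-fold higher number from compound 2 to compound 3 (0.73 log units; beyond the scatter), so this position does count on this read-out. With the fluoro pattern kept, isopropyl in place of cyclopropyl on the sulfonamide nitrogen gives a 4.1-fold higher number from compound 1 to compound 3 (0.62 log units; beyond the scatter), so the nitrogen group counts as well. No measurement at hand explains either step. Going by these compounds, whether a chloro or methoxy group on this aromatic carbon would keep the number near that of compound 2 remains open.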